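Fluoro for chloro on the phenoxy ring

The source may report more compounds than this note shows. Statements on the series, on what has been measured and on what is new or still open speak of the compounds shown alone.

Compound 1 `CCCSc1nnc(Cc2ccc(Cl)cc2Oc2ccccc2Cl)[nH]1`, compound 2 `CCCSc1nnc(Cc2ccc(Cl)cc2Oc2ccccc2F)[nH]1` and compound 3 `CCOc1nnc(Cc2ccc(Cl)cc2Oc2ccccc2Cl)[nH]1` are built on the same core and differ from one another at two places. In a functional assay on the whole organism (strain NMRI) with Mus musculus as the target, with a stated time of 60 min, at a dose of 20 mg/kg by the intraperitoneal route (a lower number here means a weaker effect, a higher number a stronger effect of the compound at the dose given), compound 1 gives 134%, compound 2 gives 133% and compound 3 gives 135%. The change from compound 1 to compound 2 is fluoro in place of chloro on an aromatic carbon; it made a step of a number 1 percentage points lower from compound 1 to compound 2 (within the scatter). The two cores differ by ethoxy in place of propylsulfanyl on an aromatic carbon, with a step of a number 1 percentage points higher from compound 1 to compound 3 (within the scatter). All three numbers sit within the usual scatter of one another, so no order among them is claimed.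

Compound 4 `CCOc1nnc(Cc2ccc(Cl)cc2Oc2ccccc2F)[nH]1` has not yet been measured in this assay. It differs from compound 3 by fluoro in place of chloro on an aromatic carbon; the place reads word for word as for the change from compound 1 to compound 2, so this is the same change carried onto the core of compound 3. The step expected from compound 3 to compound 4 is a number 1 percentage points lower from compound 3 to compound 4 (within the scatter), resting on the earlier instance of this change, which gave a number 1 percentage points lower from compound 1 to compound 2 (within the scatter). Compound 4 is thus estimated at 134%, expected to fall between 120% and 148%.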

Compound 4, a percentage reported as activity, at one dose (the size of the read-out at that dose, not a potency): 138%
Compound 4: the middle estimate sits 4 percentage points below what was measured, and the stated range covers the measured number.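

In this assay, 2-chlorophenoxy to 2-fluorophenoxy on the core of compound 3 gives a number 3 percentage points higher from compound 3 to compound 4 (within the scatter) and matches the earlier instance of this change: the same change on two cores in this assay, a number 1 percentage points lower (within the scatter) from compound 1 to compound 2 and a number 3 percentage points higher (within the scatter) from compound 3 to compound 4, 4 percentage points apart, within the scatter of two such steps
Ethoxy in place of propylsulfanyl, read on the fluoro compounds, gives a number 5 percentage points higher from compound 2 to compound 4 (within the scatter) and likewise matches its earlier instance: the same change on two cores in this assay, a number 1 percentage points higher (within the scatter) from compound 1 to compound 3 and a number 5 percentage points higher (within the scatter) from compound 2 to compound 4, 4 percentage points apart, within the scatter of two such steps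
Both changes therefore carry from one core to the other in these four compounds with no difference that can be told apart, but all the steps lie within the scatter, so this shows neither an effect of either change nor any order among the compounds, and a single dose says nothing about potency.

The compounds shown hold only chloro or fluoro on the phenoxy ring and only ethoxy or propylsulfanyl on the shared core. As far as these compounds go, whether a carboxylic acid or an amine on the phenoxy ring, or a longer chain in place of ethoxy, would move the read-out beyond the scatter remains open.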